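Fluorine in Place of Bromine on a Weak Inhibitor

This account rests on a few compounds, and the source may have more. Where it says the series, first, only, none or still open, it means among the compounds named here.

Of the compounds shown here, three have been measured in a functional assay on L1210 cells (Mus musculus) for inhibition; a higher number here means a weaker inhibitor, a lower number a stronger inhibitor. Compound 1 `O=C1/C(=C/c2ccccc2Cl)CCCc2ccccc21` gives 42300 nM in this assay. Compound 2 `O=C1/C(=C/c2ccccc2Br)CCc2ccccc21` gives 33400 nM in this assay. Compound 3 `O=C1/C(=C/c2ccc(Cl)c(Cl)c2)CCCc2ccccc21` gives 45700 nM in this assay. All three numbers are high, so each is a weak inhibitor. Compound 2 has the lowest of the three numbers, but compound 1 lies only a little above it and compound 3 only a little further, and both gaps fall within the usual scatter, so the three compounds cannot be separated by these measurements.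

Compound 4 `O=C1/C(=C/c2ccccc2F)CCc2ccccc21` has not been measured. It differs from compound 2 in one place: fluoro in place of bromo on an aromatic carbon. The change is a single halogen for another on the same aromatic carbon. Among the compounds with values here, no pair of measured compounds differs in one place only, so there is no measured step to lean on; the only guidance is that all three measured compounds, with differing halogens and differing cores, sit close together. Compound 4 is therefore expected to stay in the same region, with an expected step of a 1.3-fold higher number from compound 2 to compound 4 (0.10 log units; within the scatter), at most a small move toward a weaker inhibitor and none clearly beyond the scatter. Compound 4 is estimated at 42000 nM in this assay, with a range from 16000 nM to 110000 nM.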

Compound 4, half-maximal inhibitory concentration: 22800 nM
Compound 4: the middle estimate sits 1.8-fold (0.27 log units) above what was measured; the measured number falls inside the stated range.
By their numbers in this assay, from the lowest: compounds 4, 2, 1 and 3 (each within the scatter of the next).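

Within the data shown here, the exchange of bromo for fluoro on an aromatic carbon, ortho to a large group, provides the first readable step between two compounds that differ in one place: in this assay it is a 1.5-fold lower number from compound 2 to compound 4 (0.17 log units; within the scatter) and so does not separate the two compounds. At this position, with the core of compound 2 held constant, these two halogens therefore cannot be told apart by this measurement, and the fluoro compound remains a weak inhibitor like the bromo compound. No independent information bears on this result or offers an explanation for it.

The compounds shown leave open whether any group at this position can move the number beyond the scatter, since only halogens appear on the aromatic ring here, and an amine, a methoxy group or a carboxylic acid on the same aromatic carbon would put that to the test. On these data alone, it also remains open how the core contributes, since compound 1 and compound 3 each differ from compound 2 in more than one place and so give no clean comparison with it.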